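A few compounds are considered here, and "the series" means these few. Any claim that something is new, unique, unknown or untested is made for them only; others in the source may bear on it.

Series notes, amine and ether substituents on the shared core.

In a functional assay on HeLa cells (Homo sapiens) for antiproliferative activity, read by WST assay, with a stated time of 24 h (a lower number here means a stronger inhibitor, a higher number a weaker inhibitor), compound 1 `C=C[C@]1(C)CC[C@@H](C(=C)COCC)C[C@H]1C(=C)C` gives 106000 nM. Compound 2 `C=C[C@]1(C)CC[C@@H](C(=C)CNCCCC)C[C@H]1C(=C)C` gives 10800 nM in this assay, and compound 3 `C=C[C@]1(C)CC[C@@H](C(=C)Cn2ccnc2)C[C@H]1C(=C)C` gives 15700 nM. Compound 3 therefore stands second highest of the three numbers: its step to compound 2 is small, a 1.5-fold higher number from compound 2 to compound 3 (0.16 log units; within the scatter), while its distance from compound 1 is clear, a 6.8-fold lower number from compound 1 to compound 3 (0.83 log units; beyond the scatter). The replacement of ethoxy by butylamino, a 9.8-fold lower number from compound 1 to compound 2 (0.99 log units; beyond the scatter), is the largest step seen so far.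

Compound 4 `C=C[C@]1(C)CC[C@@H](C(=C)CNC2CCCCC2)C[C@H]1C(=C)C` differs from compound 3 as follows: cyclohexylamino in place of 1H-imidazol-1-yl on a saturated chain carbon bound to a double-bonded chain carbon. Within the data shown here, the step that bears most directly on this is the one from compound 2 to compound 3, since compound 2 also carries a secondary amine at this position, and that step lay within the scatter. The steps from compound 1 show that both amines and the imidazolyl fall well below the ether. Compound 4 is expected to sit near compound 2, so the step from compound 3 is expected to be a 1.7-fold lower number from compound 3 to compound 4 (0.24 log units; within the scatter), not clearly beyond the scatter. For compound 4 the estimate in this assay is 9000 nM, with a range from 3000 nM to 27000 nM.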

Compound 4, half-maximal inhibitory concentration: 3390 nM
The estimate for compound 4 lay 2.7-fold (0.42 log units) above the measured number; measured number inside the range.
By their numbers in this assay, from the lowest: compound 4; then compounds 2 and 3 (each within the scatter of the next); then compound 1.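

Among these compounds, at this position, on a saturated chain carbon bound to a double-bonded chain carbon, the group on the amine nitrogen affects the number in this assay: cyclohexyl in place of butyl gives (a 3.2-fold lower number from compound 2 to compound 4 (0.50 log units; beyond the scatter)), the first step beyond the scatter between two secondary amines. Cyclohexylamino also separates from 1H-imidazol-1-yl (a 4.6-fold lower number from compound 3 to compound 4 (0.67 log units; beyond the scatter)), which butylamino did not do. The whole span from the ether now reaches (a 31-fold lower number from compound 1 to compound 4 (1.50 log units; beyond the scatter)), and compound 4 has the lowest number of the four.

The compounds shown leave open whether the ring itself matters or a branched chain such as isopropyl or a smaller ring such as cyclopentyl would serve as well, and whether a phenyl group on the nitrogen or a piperidine would go lower. No supporting data bear on why the cyclohexyl group differs from the butyl group.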